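Aryl substituent steps in a cytotoxic series

This account rests on a few compounds, and the source may have more. Where it says the series, first, only, none or still open, it means among the compounds named here.

Measured in a functional assay on SK-N-SH cells (Homo sapiens) for cytotoxicity, read by MTT assay, with a stated time of 24 h; a higher number here means a weaker inhibitor, a lower number a stronger inhibitor:
- compound 1 `C/C(=N\NC(=O)/C(C#N)=C/c1ccccc1)c1c(O)c2ccc(O)cc2oc1=O`: 13500 nM
- compound 2 `COc1ccc(/C=C(\C#N)C(=O)N/N=C(\C)c2c(O)c3ccc(O)cc3oc2=O)cc1`: 9460 nM

For the measured compounds named here, compound 2 stands within the scatter of compound 1, the only other measured compound. The next change, to compound 3 `C/C(=N\NC(=O)/C(C#N)=C/c1ccc(N(C)C)cc1)c1c(O)c2ccc(O)cc2oc1=O`, is dimethylamino in place of methoxy on an aromatic carbon, para to a large group (dimethylamino in place of methoxy on an aromatic carbon). Going by the values given here, the only measured step bearing on it, methoxy in place of hydrogen, is a 1.4-fold lower number from compound 1 to compound 2 (0.15 log units; within the scatter). No step beyond the scatter is therefore expected in this assay. The estimated step is a 1.1-fold lower number from compound 2 to compound 3 (0.02 log units; within the scatter). For compound 3 the expected value is 9000 nM, with an estimated range of 4000 nM to 20000 nM.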

Compound 3, half-maximal inhibitory concentration: 6090 nM
Estimate against measurement, compound 3: 1.5-fold (0.17 log units) above; the measured number falls inside the stated range.
By their numbers in this assay, from the lowest: compounds 3, 2 and 1 (each within the scatter of the next, the first and the last beyond it).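

In this assay, the step of a 1.6-fold lower number from compound 2 to compound 3 (0.19 log units; within the scatter) stays within the scatter, so dimethylamino and methoxy at this place on the aromatic ring cannot be told apart. Dimethylamino in place of hydrogen gives the first modest step in the series beyond the scatter, a 2.2-fold lower number from compound 1 to compound 3 (0.35 log units; beyond the scatter), whereas methoxy in place of hydrogen does not leave the scatter. No available evidence accounts for either step. On these data alone, it remains open whether chlorine, a carboxylic acid or a longer chain such as butoxy at this place would extend the step from compound 1. As far as these compounds go, the same change at the other places on this aromatic ring also remains open.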